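The compounds below may be only part of what the source reports. "The series", "measured", "known", "first", "only" and "open" are said of these compounds alone.

Compound 1 `O=C(O)c1ccc(OCCOc2ccc3cc2COC/C=C/COCc2cccc(c2)-c2ccnc(n2)N3)cc1` gives > 100000 nM in an assay on Sf9 cells for inhibition of protein deacetylase HDAC6 (Homo sapiens), read by fluorescence, with a stated time of 2 h (on this read-out lower numbers stand for stronger inhibition and higher numbers for weaker inhibition), which is a limit of the measurement rather than a number (the limit of > 100000 nM in this assay, at which 1 of the 3 values shown sits). Compound 2 `O=C(O)c1cccc(NCCOc2ccc3cc2COC/C=C/COCc2cccc(c2)-c2ccnc(n2)N3)c1` gives 53000 nM in this assay. Compound 3 `O=C(CCCCCOc1ccc2cc1COC/C=C/COCc1cccc(c1)-c1ccnc(n1)N2)NO` gives 28 nM in this assay.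

Among the numbers so far, compound 3 stands lowest: its nearest neighbour is compound 2, and the step of a 1900-fold lower number from compound 2 to compound 3 (3.28 log units; beyond the scatter) is large and beyond the scatter, while an at least 3500-fold lower number from compound 1 to compound 3 (3.55 log units; beyond the scatter) is larger still. The step of an at least 1.8-fold lower number from compound 1 to compound 2 (0.27 log units; that floor lies within the scatter), between the two carboxy-bearing compounds, lies within the scatter.

Compound 4 `O=C(O)CCCCCCCOc1ccc2cc1COC/C=C/COCc1cccc(c1)-c1ccnc(n1)N2` has not yet been measured. It differs from compound 3 in one place: 2-carboxyethyl in place of hydroxycarbamoyl on a saturated chain carbon, five bonds along the chain from an oxygen on an aromatic ring. In other words, the hydroxycarbamoyl group that compound 3 carries on its chain is replaced by a chain ending in a carboxy group, as in compounds 1 and 2. Both measured steps that swap a carboxy-bearing end for hydroxycarbamoyl, an at least 3500-fold lower number from compound 1 to compound 3 (3.55 log units; beyond the scatter) and a 1900-fold lower number from compound 2 to compound 3 (3.28 log units; beyond the scatter), gave very large drops in the number, so the reverse direction is expected to raise the number sharply. Compound 4 is therefore expected to show a 1100-fold higher number from compound 3 to compound 4 (3.03 log units; beyond the scatter), landing at an estimated 30000 nM, with a range from 3000 nM to 200000 nM in this assay.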

Compound 4, half-maximal inhibitory concentration: 10000 nM
For compound 4 the middle estimate is 3.0-fold (0.48 log units) above the measured one, within the range that was stated.
By their numbers in this assay, from the lowest: compound 3; then compound 4; then compound 2. At a limit, above all of these: compound 1.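

Compounds 1 and 2 differ from compound 3 in the whole end of the chain, whereas the saturated chain is kept when 2-carboxyethyl stands in place of hydroxycarbamoyl, and a 360-fold higher number from compound 3 to compound 4 (2.55 log units; beyond the scatter) in this assay shows that a large loss remains with this simpler change. The end that carries the carboxy group still counts, though far less: 5-carboxypentyl in place of (3-carboxyphenyl)amino gives a 5.3-fold lower number from compound 2 to compound 4 (0.72 log units; beyond the scatter). The value of compound 1 is a limit of the measurement and not a number, so an at least 10-fold lower number from compound 1 to compound 4 (1.00 log units; beyond the scatter) is only a floor: the limit of > 100000 nM in this assay, at which 1 of the 4 values shown sits.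

The compounds shown leave open whether other ends on this chain, such as a primary amide, a thiol or an amine, could come close to compound 3 at 28 nM, or whether only hydroxycarbamoyl does so here. They also leave open how much chain length counts by itself, as the change from compound 3 to compound 4 alters the end group and the length together, and a shorter or longer chain ending in hydroxycarbamoyl would separate the two.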